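The source may hold more compounds than are shown below. What is called first, only, known or untested is meant among the compounds shown, and "the series" means these compounds.

Compound 1 `O=S(=O)(Nc1ccc2cc[nH]c2c1)c1ccc(Br)cc1` was tested in a functional assay on MCF7 cells (Homo sapiens) for antiproliferative activity, read by MTT assay, with a stated time of 24 h (a higher number here means a weaker inhibitor, a lower number a stronger inhibitor), where compound 1 gives 37800 nM. Compound 2 `O=C(Nc1ccc2cc[nH]c2c1)c1cccc(C(F)(F)F)c1` gives 30600 nM, and compound 3 `Cc1ccc(S(=O)(=O)Nc2ccc3cc[nH]c3c2)cc1` gives 37200 nM. On the numbers shown, compound 1 sits at the top, yet its gaps to compound 3 and to compound 2 are both within the scatter, so the three cannot be told apart. The change leading to compound 4 `O=S(=O)(Nc1ccc2cc[nH]c2c1)c1ccc(Cl)cc1` is chloro in place of bromo on an aromatic carbon. Going by the values given here, the one measured step that bears on it, a 1.0-fold lower number from compound 1 to compound 3 (0.01 log units; within the scatter), swaps the group at the same aromatic carbon and moved nothing beyond the scatter. Exchanging one halogen for another there is therefore expected to behave alike: a 1.0-fold lower number from compound 1 to compound 4 (0.01 log units; within the scatter). Compound 4 is accordingly estimated at 37000 nM, within a range from 18000 nM to 75000 nM.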

Compound 4, half-maximal inhibitory concentration: 54000 nM
Compound 4: the middle estimate sits 1.5-fold (0.16 log units) below what was measured; measured number inside the range.
By their numbers in this assay, from the lowest: compounds 2, 3, 1 and 4 (each within the scatter of the next).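

In this assay, chloro in place of bromo gives (a 1.4-fold higher number from compound 1 to compound 4 (0.15 log units; within the scatter)), and chloro in place of methyl gives (a 1.5-fold higher number from compound 3 to compound 4 (0.16 log units; within the scatter)). A second halogen therefore joins bromo and methyl on this aromatic carbon, and none of the three groups can be told apart from the others here. No measurement shown offers an explanation for these small differences. The compounds shown leave open whether an amine or a carboxylic acid on this same carbon would move the number beyond the scatter.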